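Bridged Bicyclic Amine Replaces Spirocyclic Acetal on Shared Core

The compounds below may be only part of what the source reports. "The series", "measured", "known", "first", "only" and "open" are said of these compounds alone.

Three compounds have been measured in a functional assay; on this read-out lower numbers stand for an effect already at smaller amounts and higher numbers for an effect only at larger amounts of compound:
Compound 1, `Nc1ncnc2nc(-c3ccc(N4CCC5(CC4)COCO5)nc3)cc(-c3cccc(Br)c3)c12` — 6 umol/kg
Compound 2, `COCCOC1CCN(c2ccc(-c3cc(-c4cccc(Br)c4)c4c(N)ncnc4n3)nn2)CC1` — 10 umol/kg
Compound 3, `Nc1ncnc2nc(-c3ccc(N4CCC(=NOC5CCOCC5)CC4)nn3)cc(-c3cccc(Br)c3)c12` — 7 umol/kg

Compound 1, compound 3 and compound 2 sit together on this assay: the gaps from compound 1 to compound 3 and from compound 1 to compound 2 both fall within the usual scatter of repeated measurements, so none of the three stands apart from the others.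

Compound 4, `Nc1ncnc2nc(-c3ccc(N4CC5CC4CO5)nc3)cc(-c3cccc(Br)c3)c12`, has not yet been measured. It differs from compound 1 in one place: a group of 7 heavy atoms (5 carbon, 1 nitrogen, 1 oxygen; 2 five-membered non-aromatic rings with 1 hetero atom each) in place of a group of 10 heavy atoms (7 carbon, 1 nitrogen, 2 oxygen; one five-membered non-aromatic ring with 2 hetero atoms, one six-membered non-aromatic ring with 1 hetero atom), on an aromatic carbon. The shared core and the bromophenyl group are kept; only the saturated amine substituent on the pyridine is exchanged, with the spirocyclic acetal of compound 1 giving way to a smaller bridged bicyclic ring.

Among the compounds with values here, since no pair of measured compounds differs in a single place, no measured step guides this change. The three measured numbers show that varying the amine substituent across compound 1, compound 2 and compound 3 left the read-out within scatter. Compound 4 is therefore expected to stay near compound 1, with a step of a 1.3-fold higher number from compound 1 to compound 4 (0.12 log units; within the scatter) that is not expected to exceed the scatter. The estimate for compound 4 is 8 umol/kg, with a range from 3 umol/kg to 20 umol/kg.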

Compound 4, dose for half-maximal effect: 8 umol/kg
Estimate against measurement, compound 4: no gap at the digits printed, and the stated range covers the measured number.
By their numbers in this assay, from the lowest: compounds 1, 3, 4 and 2 (each within the scatter of the next).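

In this assay, within the data shown here, the only comparison so far between compounds differing in one place gives a 1.3-fold higher number from compound 1 to compound 4 (0.12 log units; within the scatter), so replacing the spirocyclic acetal with the smaller bridged bicyclic amine leaves the read-out within the scatter. At this place, on an aromatic carbon next to the ring nitrogen, a group of 7 heavy atoms with 2 hydrogen-bond acceptors and a group of 10 heavy atoms with 3 cannot be told apart on this read-out. No measurement is available that would account for this result.

From the compounds shown here alone, it remains open whether a piperazine, a primary amine or a carboxylic acid-bearing ring at this place would also stay within the scatter of compound 1. Going by these compounds, it is equally open whether the same holds when the bromine on the phenyl group gives way to a nitrile.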